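Chlorinated hydrazones: compound 2 to compound 3 step

A few compounds are considered here, and "the series" means these few. Any claim that something is new, unique, unknown or untested is made for them only; others in the source may bear on it.

Measured so far:
compound 1 `O=C(N/N=C/C1=C(Cl)c2ccccc2CCC1)c1ccccc1` gives 11100 nM
compound 2 `Cc1cc2c(cc1C)C(Cl)=C(/C=N/NC(=O)c1ccccc1)CCC2` gives 2500 nM

Two compounds have numbers in a functional assay on MDA-MB-231 cells (Homo sapiens) for inhibition, read by sulforhodamine B assay, with a stated time of 48 h; a lower number here means a stronger inhibitor of growth, a higher number a weaker inhibitor of growth. Compound 2 stands lowest of the two; its nearest neighbour is compound 1, whose number is higher by a margin beyond the usual scatter. Going by the values given here, compound 1 and compound 2 differ in more than one place, so the two values show only that compound 2 is the stronger inhibitor of growth in this assay.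

The next compound, compound 3 `Cc1cc2c(cc1C)C(Cl)=C(/C=N/NC(=O)c1cccc(Cl)c1)CCC2`, is not yet measured. It differs from compound 2 in one place: chloro in place of hydrogen on an aromatic carbon. Cut one bond further out, the change reads phenyl to 3-chlorophenyl.

Among the compounds with values here, no step between measured compounds speaks to this change, so no size can be read from the data. A small step, within or near the scatter, is expected in this assay, if anything toward a lower number. For compound 3 the estimated value in this assay is 1800 nM, with a range from 600 nM to 5400 nM, the expected step being a 1.4-fold lower number from compound 2 to compound 3 (0.14 log units; within the scatter).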

Compound 3, concentration for 50% growth inhibition: 1930 nM
Beside the measured number, compound 3's estimate is 1.1-fold (0.03 log units) below it; the range from low to high includes it.
By their numbers in this assay, from the lowest: compounds 3 and 2 (each within the scatter of the next); then compound 1.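

In this assay the series now has its first comparison of compounds that differ in one place: chloro in place of hydrogen on an aromatic carbon, meta to a large group, gives a 1.3-fold lower number from compound 2 to compound 3 (0.11 log units; within the scatter) on the core of compound 2. This position therefore accepts a chloro, a single added heavy atom, without a separation between compound 2 and compound 3 in growth inhibition, and phenyl and 3-chlorophenyl cannot be told apart here. No measurement on these compounds gives a reason for the size of this step.

On these data alone, one chloro at one place says little about how far this position can be changed, so a methoxy group, an amine, a carboxylic acid or a longer chain there remains open, as does a chloro elsewhere on the phenyl ring. As far as these compounds go, whether phenyl to 3-chlorophenyl reads the same on the core of compound 1 also stays open.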